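A few compounds are considered here, and "the series" means these few. Any claim that something is new, unique, unknown or untested is made for them only; others in the source may bear on it.

In a functional assay on HEL cells (Homo sapiens) for inhibition, read by CellTiter-Glo, with a stated time of 48 h (a lower number here means a stronger inhibitor of growth, a higher number a weaker inhibitor of growth), compound 1 (`O=C(CCCCC(=O)N1C/C=C/COCc2cccc(c2)-c2ccnc(n2)Nc2cccc(c2)C1)NO`) gives 2940 nM, level within the scatter with compound 3 (`O=C(CCCCC(=O)N1C/C=C/CCOc2cccc(c2)-c2ccnc(n2)Nc2cccc(c2)C1)NO`) at 2110 nM, while compound 2 (`O=C(CCCCN1C/C=C/CCOc2cccc(c2)-c2ccnc(n2)Nc2cccc(c2)C1)NO`) shows a lower number, 510 nM. Compound 4 (`O=C(CCCCCCCC(=O)N1C/C=C/COCc2cccc(c2)-c2ccnc(n2)Nc2cccc(c2)C1)NO`) differs from compound 1 by 3-(hydroxycarbamoyl)propyl in place of hydroxycarbamoyl on a saturated chain carbon, four bonds along the chain from a carbonyl carbon: 3-(hydroxycarbamoyl)propyl in place of hydroxycarbamoyl on a saturated chain carbon. For the measured compounds named here, no measured step lengthens this chain. Going by the values given here, the only measured step touching the chain that bears the hydroxycarbamoyl group is a 4.1-fold higher number from compound 2 to compound 3 (0.62 log units; beyond the scatter), so a step no larger than that is expected in this assay, tentatively towards a lower number, as the data do not fix the direction. The expected change is a 2.3-fold lower number from compound 1 to compound 4 (0.35 log units; beyond the scatter). For compound 4 the estimate is 1300 nM, with an expected range of 450 nM to 3500 nM.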

Compound 4, concentration for 50% growth inhibition: 4780 nM
Estimate against measurement, compound 4: 3.7-fold (0.57 log units) below; the measured number lies above the stated range.
By their numbers in this assay, from the lowest: compound 2; then compounds 3, 1 and 4 (each within the scatter of the next, the first and the last beyond it).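

In this assay, putting 3-(hydroxycarbamoyl)propyl in place of hydroxycarbamoyl on this saturated chain carbon gives a 1.6-fold higher number from compound 1 to compound 4 (0.21 log units; within the scatter), the only step shown that varies chain length. For the compounds shown here, at this position, then, the added length leaves the two compounds level, a result the earlier compounds could not show. Nothing available explains this result.

The compounds shown leave open whether a carboxylic acid in place of hydroxycarbamoyl would read differently. They also leave open whether the longer chain behaves alike without the carbonyl on the amine nitrogen in the ring.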